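The source may hold more compounds than are shown below. What is called first, only, known or untested is meant among the compounds shown, and "the series" means these compounds.

Of the compounds shown here, three have been measured in a functional assay on MDA-MB-231 cells (Homo sapiens) for cytotoxicity, read by MTT assay, with a stated time of 72 h; a higher number here means a weaker inhibitor, a lower number a stronger inhibitor. Compound 1 `COc1ccc(/C=C/c2cc(C)no2)cc1OC` gives 79900 nM, the highest of the three numbers. Compound 2 `COc1cc(/C=C/c2cc(C)[nH]n2)ccc1O` gives 67000 nM, which sits so close to compound 1 that the two cannot be told apart within the usual scatter of this assay. Compound 3 `CC(=O)/C=C(O)/C=C/c1ccc(O)c(O)c1` gives 32200 nM, a number further from compound 1 than the scatter allows, so compound 3 does stand apart from compound 1 on this read-out.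

Compound 4 `COc1ccc(/C=C/C(=O)CC(C)=O)cc1OC` has not yet been measured in this assay. It differs from compound 1 in a single place: (2-oxopropyl)carbonyl in place of 3-methyl-1,2-oxazol-5-yl on a double-bonded chain carbon bound to a double-bonded chain carbon. Among the compounds with values here, no pair of measured compounds differs in exactly one place, so no measured step of this kind exists to lean on. What can be said is that the measured compound whose chain most resembles the group entering in compound 4 is compound 3, and compound 3 gives 32200 nM, while compound 1 gives 79900 nM.

On that basis the number for compound 4 is expected to move toward a lower value, by a step of a 1.8-fold lower number from compound 1 to compound 4 (0.25 log units; within the scatter), small enough that it may not clear the scatter. Compound 4 is estimated at 45000 nM, with a range from 15000 nM to 130000 nM.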

Compound 4, half-maximal inhibitory concentration: 43100 nM
For compound 4 the middle estimate is 1.0-fold (0.02 log units) above the measured one; low and high end bracket the measured number.
By their numbers in this assay, from the lowest: compounds 3, 4, 2 and 1 (each within the scatter of the next, the first and the last beyond it).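

On a double-bonded chain carbon bound to a double-bonded chain carbon, the change from 3-methyl-1,2-oxazol-5-yl to (2-oxopropyl)carbonyl gives, in this assay, a 1.9-fold lower number from compound 1 to compound 4 (0.27 log units; within the scatter). Within the data shown here, this is the first one-place comparison, and it shows that an open chain can stand where the five-membered aromatic ring stood without a step that clears the scatter, at least in this single pair, where both groups have the same counts of heavy atoms and hydrogen-bond acceptors. Nothing available explains this result or shows what the exchange does beyond this read-out.

Among these compounds, the single step leaves open whether any other group at this place, such as a carboxylic acid, an amide or a longer chain, would give a number that stands clear of compound 1. It also leaves open whether the same exchange would give a similar step on the core of compound 2, whose ring substituents differ from those of compound 1 and compound 4.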